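The source may hold more compounds than are shown below. What is called first, only, known or untested is meant among the compounds shown, and "the series" means these compounds.

Working notes on the series. The shared core carries a piperidine-type amide nitrogen bearing a carbonyl, and the three measured compounds differ only in what sits on that carbonyl carbon. Compound 1 `Cc1nc(S(C)(=O)=O)ccc1Oc1ncnc(OC2CCN(C(=O)OC3CCC3)CC2)c1F` gives in a functional assay on isolated protein for inhibition of Glucose-dependent insulinotropic receptor (Rattus norvegicus), read by HTRF and cAMP accumulation (on this read-out lower numbers stand for smaller maximal responses and higher numbers for larger maximal responses), a value of 81%. Compound 2 `CCC1(OC(=O)N2CCC(Oc3ncnc(Oc4ccc(S(C)(=O)=O)nc4C)c3F)CC2)CC1` gives in this assay a value of 83%, the step being a number 2 percentage points higher from compound 1 to compound 2 (within the scatter). Compound 3 `Cc1nc(S(C)(=O)=O)ccc1Oc1ncnc(OC2CCN(C(=O)SC3(C)CC3)CC2)c1F` gives in this assay a value of 77%; the steps to it are a number 4 percentage points lower from compound 1 to compound 3 (within the scatter) and a number 6 percentage points lower from compound 2 to compound 3 (within the scatter). Compound 3 thus stands with the other two, none of the three separated from another by more than the scatter allows.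

Compound 4 `Cc1nc(S(C)(=O)=O)ccc1Oc1ncnc(OC2CCN(C(=O)c3ncc(Cl)cn3)CC2)c1F` is not yet measured. Its change from compound 3 is a group of 7 heavy atoms (4 carbon, 2 nitrogen, 1 chlorine; one six-membered aromatic ring with 2 hetero atoms) in place of a group of 5 heavy atoms (4 carbon, 1 sulfur; one three-membered non-aromatic ring of carbon only), on a carbonyl carbon. The three measured steps all concern the same position and all stayed within the scatter, which suggests the maximal response has so far been insensitive to what is attached there. None of them, however, exchanged a non-aromatic ring for an aromatic one, so the present step is not directly covered. The expectation is therefore a step of a number 3 percentage points higher from compound 3 to compound 4 (within the scatter) in this assay, that is, none beyond the scatter, with a wider range to reflect the untested type of change. Compound 4 is estimated at 80%, between 65% and 95%.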

Compound 4, largest response reached (reported as efficacy), in percent of the reference or control that the assay uses: 77%
The estimate for compound 4 lay 3 percentage points above the measured number, within the range that was stated.
By their numbers in this assay, from the lowest: compounds 3, 4, 1 and 2 (each within the scatter of the next).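

In this assay, among the compounds shown here, the exchange for 5-chloropyrimidin-2-yl puts a six-membered aromatic ring on the carbonyl carbon for the first time in these four compounds, and it gives no change at the digits printed from compound 3 to compound 4 (within the scatter) even though a non-aromatic ring leaves and an aromatic one enters. The picture is the same against the two oxygen-linked groups, with a number 6 percentage points lower from compound 2 to compound 4 (within the scatter) and a number 4 percentage points lower from compound 1 to compound 4 (within the scatter) in the same assay, so the maximal response stays within the scatter across all four compounds, also when the ring sits directly on the carbonyl carbon with no oxygen or sulfur as a link. Nothing available bears on why the response holds across these groups.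

From the compounds shown here alone, whether an amine, a carboxylic acid or a longer chain on the carbonyl carbon would hold the response in the same way remains open, as does what the chlorine contributes to 5-chloropyrimidin-2-yl. The compounds shown speak only to the maximal response in this assay and say nothing about changes elsewhere on the shared core.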